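Changing the oxygen-linked group of compound 2

The source may report more compounds than this note shows. Statements on the series, on what has been measured and on what is new or still open speak of the compounds shown alone.

Compound 2 (`CNC(=O)c1cc(Oc2ccc(NC(=O)c3nn(-c4ccccc4OC(F)(F)F)c(=O)cc3C)cc2F)ccn1`) reads > 40000 nM in a functional assay on MCF7 cells (Homo sapiens) for cytotoxicity, read by MTT assay, with a stated time of 72 h (on this read-out higher numbers stand for weaker inhibition and lower numbers for stronger inhibition), and this is a limit of the assay, not a number. It therefore stands at the limit of > 40000 nM in this assay, at which 1 of the 3 values shown sits. In this assay, compound 1 (`CNC(=O)c1cc(Oc2ccc(NC(=O)c3nn(-c4ccc(Br)cc4F)c(=O)cc3C)cc2F)ccn1`) gives 9360 nM and compound 3 (`CNC(=O)c1cc(Oc2ccc(NC(=O)c3nn(-c4cccc(F)c4)c(=O)cc3C)cc2F)ccn1`) gives 6410 nM.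

Compound 4 (`Cc1cc(=O)n(-c2ccccc2OC(F)(F)F)nc1C(=O)Nc1ccc(Oc2ncnc3ccsc23)c(F)c1`) keeps the 2-(trifluoromethoxy)phenyl of compound 2 but differs on an oxygen on an aromatic ring, where 2-(methylcarbamoyl)pyridin-4-yl leaves: a group of 9 heavy atoms (6 carbon, 2 nitrogen, 1 sulfur; one five-membered aromatic ring with 1 hetero atom, one six-membered aromatic ring with 2 hetero atoms) in place of a group of 10 heavy atoms (7 carbon, 2 nitrogen, 1 oxygen; one six-membered aromatic ring with 1 hetero atom), on an oxygen on an aromatic ring.

Going by the values given here, no measured step makes this change. All three swap the group on an aromatic nitrogen instead: an at least 4.2-fold higher number from compound 1 to compound 2 (0.63 log units; beyond the scatter) and an at least 6.2-fold lower number from compound 2 to compound 3 (0.79 log units; beyond the scatter) lie beyond the scatter, while a 1.5-fold lower number from compound 1 to compound 3 (0.16 log units; within the scatter) lies within it. They bear on the question only indirectly, showing how far a change elsewhere in the molecule can move the reading. Taking an at least 6.2-fold lower number from compound 2 to compound 3 (0.79 log units; beyond the scatter) as a rough guide to size, a modest move to a lower number is expected in this assay, with low confidence, and a second reading at the limit remains quite possible. The expected change is an at least 2.6-fold lower number from compound 2 to compound 4 (0.42 log units; beyond the scatter). The estimate for compound 4 is 15000 nM, with an expected range of 3000 nM to 40000 nM.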

Compound 4, half-maximal inhibitory concentration: 11500 nM
Estimate against measurement, compound 4: 1.3-fold (0.12 log units) above, and the stated range covers the measured number.
By their numbers in this assay, from the lowest: compounds 3, 1 and 4 (each within the scatter of the next). At a limit, above all of these: compound 2.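

Swapping the 2-(methylcarbamoyl)pyridin-4-yl on the oxygen on an aromatic ring for the new group of 9 heavy atoms gives an at least 3.4-fold lower number from compound 2 to compound 4 (0.54 log units; beyond the scatter) in this assay, with the 2-(trifluoromethoxy)phenyl left in place. Going by these compounds alone, the earlier steps all changed the group on an aromatic nitrogen, so this is the first sign that the group on the oxygen can also move the reading beyond the scatter, and that a compound carrying 2-(trifluoromethoxy)phenyl can give a reading short of the limit. The reading of compound 2, the starting point of this step, is a limit of the assay and not a number: the limit of > 40000 nM in this assay, at which 1 of the 4 values shown sits.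

On these data alone, it remains open whether the same swap would move the reading in the same direction with 3-fluorophenyl or 4-bromo-2-fluorophenyl on the aromatic nitrogen, as the new group appears here only with 2-(trifluoromethoxy)phenyl. Also open, as far as these compounds go, is how other groups on that oxygen would read, such as a plain phenyl or a pyridin-4-yl carrying an amine or a carboxylic acid in place of the methylcarbamoyl.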